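A few compounds are considered here, and "the series" means these few. Any claim that something is new, unique, unknown or untested is made for them only; others in the source may bear on it.

Measured in a functional assay on SH-SY5Y cells (Homo sapiens) for cytotoxicity, read by MTT assay, with a stated time of 72 h; a higher number here means a weaker inhibitor, a lower number a stronger inhibitor:
- compound 1 `O=C1c2c[n+]([O-])c3ccccc3c2C(=O)c2c1c1ccccc1n2CCN1CCCC1`: 520 nM
- compound 2 `CCCCN1CCN(CCCCn2c3c(c4ccccc42)C(=O)c2c[n+]([O-])c4ccccc4c2C3=O)CC1`: 6100 nM

Among the compounds with values here, compound 2 holds the higher of the two numbers, and the only measured step is a 12-fold higher number from compound 1 to compound 2 (1.07 log units; beyond the scatter). That step put 2-(4-butylpiperazin-1-yl)ethyl in place of pyrrolidin-1-yl on a saturated chain carbon, two bonds along the chain from an aromatic nitrogen.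

Compound 3 `O=C1c2c[n+]([O-])c3ccccc3c2C(=O)c2c1c1ccccc1n2CCCCN1CCCCC1` is the next case: piperidin-1-yl in place of 4-butylpiperazin-1-yl on a saturated chain carbon, four bonds along the chain from an aromatic nitrogen. Here piperidin-1-yl takes the place of 4-butylpiperazin-1-yl on a saturated chain carbon, four bonds along the chain from an aromatic nitrogen. The chain of compound 2 stays, so the change undoes only part of the measured step. Within the data shown here, no measured pair isolates the ring group alone, and this single step is thin support. The direction in this assay is expected to be towards a lower number, with compound 1 at 520 nM as the reference on that side. The expected size is smaller than the measured step, an estimated 3.8-fold lower number from compound 2 to compound 3 (0.58 log units; beyond the scatter). Compound 3 is estimated at 1600 nM, with an expected range of 500 nM to 5000 nM.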

Compound 3, half-maximal inhibitory concentration: 230 nM
Estimate against measurement, compound 3: 7.0-fold (0.84 log units) above; the whole stated range lies above it.
By their numbers in this assay, from the lowest: compound 3; then compound 1; then compound 2.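

In this assay, piperidin-1-yl in place of 4-butylpiperazin-1-yl on a saturated chain carbon, four bonds along the chain from an aromatic nitrogen, gives a 27-fold lower number from compound 2 to compound 3 (1.42 log units; beyond the scatter) with the chain unchanged, so this step isolates the ring group, which the earlier step between compound 1 and compound 2 could not do. With 2-(piperidin-1-yl)ethyl in place of pyrrolidin-1-yl on a saturated chain carbon, two bonds along the chain from an aromatic nitrogen, the series shows a 2.3-fold lower number from compound 1 to compound 3 (0.35 log units; beyond the scatter) and this modest step shows that the longer chain of compound 3 does not by itself bring a higher number. No measurement shown here accounts for the size or direction of either step.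

The compounds shown leave open whether the higher number of compound 2 goes with the butyl group or with the second ring nitrogen of 4-butylpiperazin-1-yl, a question that piperazin-1-yl or morpholin-4-yl on the same chain would address. They also do not separate the shares of chain and ring group in the step to compound 3, for which pyrrolidin-1-yl on that same chain would be the matching case.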